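The source may report more compounds than this note shows. Statements on the series, on what has been measured and on what is new or still open speak of the compounds shown alone.

Working notes on the series, read in a functional assay on MCF7 cells (Homo sapiens) for cytotoxicity, with a stated time of 72 h; on this read-out higher numbers stand for weaker inhibition and lower numbers for stronger inhibition. Compound 1 (`Cc1cccc(-c2nn3c(c2-c2ccncc2)C(CO)C(C)(C)C3)n1`) gives > 100000 nM as a limit of the assay and not a number. Compound 2 (`Cc1cc(-c2c(-c3cccc(C)n3)nn3c2C(C)C(C)(C)C3)ccn1`) gives > 100000 nM and this too is a limit. Within the data shown here, compound 3 (`Cc1cccc(-c2nn3c(c2-c2ccncc2)C(C)C(C)(C)C3)c1C#N`) is the only one with a number so far, at 97000 nM in this read-out. Compound 1 therefore stands at the limit of > 100000 nM in this assay, at which 2 of the 3 values shown sit, and has no exact place on the scale.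

The next compound is compound 4 (`Cc1cccc(-c2nn3c(c2-c2ccncc2)CC(C)(C)C3)n1`). The change is hydrogen in place of hydroxymethyl on a saturated ring carbon and amounts to hydrogen in place of hydroxymethyl on a saturated ring carbon. Among the measured compounds shown here, no measured pair differs in one place, so no size for this change can be read from the series. No shift beyond the scatter is expected in this assay, and no direction is favoured. For the measured compounds named here, compound 3 at 97000 nM is the sole guide to where a number would fall. The expected size of the change is an at least 1.1-fold lower number from compound 1 to compound 4 (0.04 log units; that floor lies within the scatter) and remains an estimate. A report as a limit is thought more likely than not, and compound 4 is expected at 90000 nM with an estimated range from 40000 nM to 200000 nM in this assay.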

Compound 4, half-maximal inhibitory concentration: > 100000 nM
Compound 4: only a limit was reported; the forecaster's own chance of this, stated with the estimate: 60%; middle value at least 1.1-fold (0.04 log units) from the limit.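

Compound 1 and compound 4 both stand as limits and not as numbers in this assay, so no step can be read between them: the limit of > 100000 nM in this assay, at which 3 of the 4 values shown sit.

The compounds shown leave open how large a shift, if any, hydrogen in place of hydroxymethyl produces on this read-out.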